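Sulfonamide to amide on a trimethoxyphenyl benzimidazole scaffold

The source may hold more compounds than are shown below. What is called first, only, known or untested is meant among the compounds shown, and "the series" means these compounds.

Measured compounds:
compound 1 `COc1cc(N(Cc2nc3ccccc3[nH]2)S(=O)(=O)c2ccc(F)cc2)cc(OC)c1OC`, 9380 nM
compound 2 `COc1cc(N(Cc2nc3ccccc3[nH]2)S(=O)(=O)c2ccc(C(C)(C)C)cc2)cc(OC)c1OC`, 33600 nM
compound 3 `COc1ccc(S(=O)(=O)N(Cc2nc3ccccc3[nH]2)c2cc(OC)c(OC)c(OC)c2)cc1OC`, 47700 nM

In a functional assay on MCF7 cells (Homo sapiens) for inhibition, read by MTT assay, with a stated time of 48 h (a higher number here means a weaker inhibitor, a lower number a stronger inhibitor), compound 1 gives 9380 nM, the lowest of the three numbers. Changing only the aryl group on the sulfonyl sulfur moved the number upward in both measured cases: a 3.6-fold higher number from compound 1 to compound 2 (0.55 log units; beyond the scatter) and a 5.1-fold higher number from compound 1 to compound 3 (0.71 log units; beyond the scatter), each beyond the scatter but modest. Compound 2 and compound 3 lie within the scatter of each other.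

Compound 4 `COc1cc(N(Cc2nc3ccccc3[nH]2)C(=O)c2ccc(Br)cc2)cc(OC)c1OC` differs from compound 1 in another way: (4-bromophenyl)carbonyl in place of (4-fluorophenyl)sulfonyl on a nitrogen on an aromatic ring. Here the sulfonyl link itself is replaced by a carbonyl, and the fluorine by bromine. For the measured compounds named here, no measured step alters the link between the aromatic nitrogen and the aryl group, so the two measured steps bear on this change only loosely: they show that the shared core of compound 1 tolerates variation on that aryl group at the cost of a modest rise in the number, without any case of improvement.

Compound 4 is therefore expected to give 16000 nM in this assay, between 4000 nM and 65000 nM, a step of a 1.7-fold higher number from compound 1 to compound 4 (0.23 log units; within the scatter) that is estimated with low confidence.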

Compound 4, half-maximal inhibitory concentration: > 50000 nM
Compound 4: only a limit was reported; the forecaster's own chance of this, stated with the estimate: 10%; middle value at least 3.1-fold (0.49 log units) away from the limit.
By their numbers in this assay, from the lowest: compound 1; then compounds 2 and 3 (each within the scatter of the next). At a limit, above all of these: compound 4.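

In this assay compound 4 gives only a limit of > 50000 nM and not a number. Replacing (4-fluorophenyl)sulfonyl with (4-bromophenyl)carbonyl on the nitrogen gives an at least 5.3-fold higher number from compound 1 to compound 4 (0.72 log units; beyond the scatter) and is the first step shown that alters the link itself rather than only the aryl group; like both earlier changes from compound 1, it moves the number upward, and no change at this position has yet lowered it. The link and the halogen change together in this single step, so the result does not separate them, and it adds the only value of its kind among the compounds shown: the limit of > 50000 nM in this assay, at which 1 of the 4 values shown sits.

Going by these compounds, it remains open whether a (4-fluorophenyl)carbonyl or a (4-bromophenyl)sulfonyl group on this nitrogen would stay near compound 1, and what a benzyl group or an unsubstituted amine at the same place would do. On these data alone, how far compound 4 lies past its limit also remains open, and steps from compound 2 or compound 3 to compound 4 cannot be read.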